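Chloro to fluoro on the benzothiazole amide of compound 1

The compounds below may be only part of what the source reports. "The series", "measured", "known", "first", "only" and "open" are said of these compounds alone.

Measured compounds:
compound 1 `COc1ccc(-c2cc(C(=O)Nc3nc4ccc(Cl)cc4s3)nc3cc(-c4ccccc4)nn23)cc1` — 3090 nM
compound 2 `COc1cc(-c2cc(C(=O)Nc3nc4ccc(Cl)cc4s3)nc3cc(-c4ccccc4)nn23)cc(OC)c1OC` — 18200 nM

In a functional assay on A549 cells (Homo sapiens) for cytotoxicity, read by MTT assay, with a stated time of 48 h (on this read-out higher numbers stand for weaker inhibition and lower numbers for stronger inhibition), compound 1 gives the lowest of the two numbers recorded; its nearest neighbour is compound 2, reached by a 5.9-fold higher number from compound 1 to compound 2 (0.77 log units; beyond the scatter) after 3,4,5-trimethoxyphenyl replaces 4-methoxyphenyl on an aromatic carbon. Compound 3 `COc1ccc(-c2cc(C(=O)Nc3nc4ccc(F)cc4s3)nc3cc(-c4ccccc4)nn23)cc1` is not yet measured in this assay. It differs from compound 1 by fluoro in place of chloro on an aromatic carbon. For the measured compounds named here, no measured step touches this halogen position; the single step from compound 1 to compound 2 concerns the other end of the shared core and therefore gives no direct guide to the size or direction of the present change. With one halogen exchanged for another at the same aromatic carbon, the working expectation is a step no larger than the usual scatter, a 1.3-fold higher number from compound 1 to compound 3 (0.11 log units; within the scatter), and compound 3 is estimated at 4000 nM, within a range from 1500 nM to 12000 nM.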

Compound 3, half-maximal inhibitory concentration: 11700 nM
Compound 3: middle estimate off by 2.9-fold (0.47 log units), on the low side; measured number inside the range.
By their numbers in this assay, from the lowest: compound 1; then compounds 3 and 2 (each within the scatter of the next).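

In this assay the change from 6-chloro-1,3-benzothiazol-2-yl to 6-fluoro-1,3-benzothiazol-2-yl gives a 3.8-fold higher number from compound 1 to compound 3 (0.58 log units; beyond the scatter), so the exchange of one halogen atom at this aromatic carbon registers beyond the scatter. Until now the only step shown lay at the other end of the shared core, a 5.9-fold higher number from compound 1 to compound 2 (0.77 log units; beyond the scatter), and this halogen position now proves responsive as well, with chloro giving the lower number of the two halogens on the core of compound 1. Nothing available accounts for the size or direction of this step.

From the compounds shown here alone, whether the number follows any order across other substituents at this carbon stays open, since bromo, methyl or an amine there would extend the comparison beyond two halogens. Also open, going by these compounds, is whether the same exchange gives a similar step alongside 3,4,5-trimethoxyphenyl.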